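This account rests on a few compounds, and the source may have more. Where it says the series, first, only, none or still open, it means among the compounds named here.

Two compounds carry numbers in an ADME assay on L02 cells (Homo sapiens) for cytotoxicity, read by MTT assay, with a stated time of 48 h; a higher number here means a weaker inhibitor, a lower number a stronger inhibitor. Compound 1 `CCn1c(C(=O)NCC(OC)OC)ccc1C(CC)(CC)c1ccc(OCC(O)C(C)(C)C)c(C)c1` gives 22200 nM, the higher of the two, while compound 2 `CC[C@@H](C)[C@H](NC(=O)c1ccc(C(CC)(CC)c2ccc(OCC(=O)C(C)(C)C)c(C)c2)n1CC)C(=O)O` gives 1500 nM, a gap beyond the scatter. Compound 3 `CCn1c(C(=O)OCc2ccc(F)cc2)ccc1C(CC)(CC)c1ccc(OCC(O)C(C)(C)C)c(C)c1` has not yet been measured there. It differs from compound 1 in one place: (4-fluorobenzyl)oxy in place of (2,2-dimethoxyethyl)amino on a carbonyl carbon. Going by the values given here, no pair of measured compounds spans this change, so nothing measured shows its size. The step expected is a 1.9-fold lower number from compound 1 to compound 3 (0.27 log units; within the scatter), a modest move toward a lower number, not far beyond the scatter. Compound 3 is therefore estimated at 12000 nM in this assay, within a range of 4000 nM to 40000 nM.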

Compound 3, half-maximal inhibitory concentration: 14900 nM
The estimate for compound 3 lay 1.2-fold (0.09 log units) below the measured number; measured number inside the range.
By their numbers in this assay, from the lowest: compound 2; then compounds 3 and 1 (each within the scatter of the next).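

In this assay, (4-fluorobenzyl)oxy in place of (2,2-dimethoxyethyl)amino on a carbonyl carbon gives a 1.5-fold lower number from compound 1 to compound 3 (0.17 log units; within the scatter). At this place, a group with one six-membered aromatic ring and no hydrogen-bond donor therefore reads the same, within the scatter, as a group with no ring and one hydrogen-bond donor. Nothing available explains this result. On these data alone, whether a carboxylic acid or a simple amine on this carbonyl carbon would also stay within the scatter of compound 1 remains open. So does what a benzyloxy group without fluorine would give.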